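Swapping Bromo for Fluoro: What to Expect for Compound 3

This account rests on a few compounds, and the source may have more. Where it says the series, first, only, none or still open, it means among the compounds named here.

compound 1 `O=C1NC(=S)/C(=C/c2ccccc2Br)S1`: 13.3%
compound 2 `O=C1NC(=S)/C(=C/c2cccc(F)c2)S1`: 2.1%

For the measured compounds named here, in a functional assay on NCI-H292 cells (Homo sapiens) for cytotoxicity, read by MTT assay, with a stated time of 72 h, tested at 1.25 ug/mL (a lower number here means less inhibition of growth, a higher number more inhibition of growth at the concentration tested), compound 1 gives 13.3%, the higher of the two numbers so far. Compound 2 gives 2.1%, a value lower by more than the usual scatter. Compound 3 `O=C1NC(=S)/C(=C/c2ccccc2F)S1` has not yet been measured. It differs from compound 1 by fluoro in place of bromo on an aromatic carbon. Going by the values given here, no measured pair shows this exact change, so its size is uncertain, but a step toward less growth inhibition seems likely, since the other fluoro compound, compound 2, gives 2.1%. Compound 3 is therefore expected at about 6%, within 0% to 16%. This estimate means an expected step of a number 7.3 percentage points lower from compound 1 to compound 3 (within the scatter).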

Compound 3, percent growth inhibition at one concentration: 4.29%
For compound 3 the middle estimate is 1.7 percentage points above the measured one; measured number inside the range.
By their numbers in this assay, from the lowest: compounds 2, 3 and 1 (each within the scatter of the next, the first and the last beyond it).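

On this aromatic carbon, ortho to a group of 8 heavy atoms, fluoro in place of bromo gives a number 9 percentage points lower from compound 1 to compound 3 (within the scatter) in this assay. For the compounds shown here, this is the first direct measure of the change, and it shows that exchanging one of these two halogens for the other at this position does not move the result clearly beyond normal assay variation. No available evidence bears on this result. The compounds shown leave open what an amine or a carboxylic acid on this same carbon would give, and whether any group there would produce a step beyond the scatter.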